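The compounds below may be only part of what the source reports. "The series", "measured", "known", "first", "only" and "open" are said of these compounds alone.

Going by the values given here, compound 2, `CCC(Nc1nnc(-c2ccc(OC)cc2)o1)[C@H]1CC[C@@H](c2ccnc3ccc(C(F)(F)F)cc32)CC1`, gives 6 nM in an assay on tissue (M109 cells) for inhibition of Indoleamine 2,3-dioxygenase 1 (Mus musculus), read by fluorescence, with a stated time of 18 h (a lower number here means a stronger inhibitor, a higher number a weaker inhibitor), and stands lowest of the two numbers measured so far. The nearest measured neighbour is compound 1, `COCC(Nc1nnc(-c2ccc(OC)cc2)o1)[C@H]1CC[C@@H](c2ccnc3ccc(F)cc32)CC1`, which in this assay gives 44 nM; the two compounds differ in more than one place, so their values are compared only as they stand, with compound 1 the higher number by a margin beyond the usual scatter.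

The step to compound 3, `CCC(Nc1nnc(-c2ccc(OC)cc2)o1)[C@H]1CC[C@@H](c2ccnc3ccc(F)cc32)CC1`, is fluoro in place of trifluoromethyl on an aromatic carbon. Among the compounds with values here, no measured pair shows this change on its own. Since compound 1 also carries fluoro at that place and gives 44 nM, an increase in the number is expected for compound 3, though a modest one. The step expected for compound 3 is estimated as a 3.0-fold higher number from compound 2 to compound 3 (0.48 log units; beyond the scatter). The estimate for compound 3 in this assay is 18 nM, within a range of 6 nM to 55 nM.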

Compound 3, half-maximal inhibitory concentration: 31 nM
The estimate for compound 3 lay 1.7-fold (0.24 log units) below the measured number, and the stated range covers the measured number.
By their numbers in this assay, from the lowest: compound 2; then compounds 3 and 1 (each within the scatter of the next).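

In this assay, fluoro in place of trifluoromethyl on an aromatic carbon can now be read on its own, and it gives a 5.2-fold higher number from compound 2 to compound 3 (0.71 log units; beyond the scatter), so the trifluoromethyl group at this place carries the lower number. Methyl in place of methoxy on the saturated chain carbon gives a 1.4-fold lower number from compound 1 to compound 3 (0.15 log units; within the scatter), so of the two single changes now readable, only the one on the aromatic carbon moves the number beyond the scatter. No measurement shown here explains either step.

The compounds shown leave open how chloro, a nitrile or an amine would read on that aromatic carbon. They also leave open how a hydroxyl group or a longer chain would read on the saturated chain carbon, and whether the trifluoromethyl step would be the same with methoxy on that chain.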